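The source may report more compounds than this note shows. Statements on the series, on what has been measured and on what is new or still open speak of the compounds shown alone.

Compound 3 `CCOC(=O)[C@@]1(C(=O)Nc2ccccc2)C[C@H]1c1cc(OC)c(OC)c(OC)c1` and compound 1 `COc1cc([C@@H]2C[C@@]2(CO)C(=O)Nc2ccccc2)cc(OC)c1OC` share a core and differ by hydroxymethyl in place of ethoxycarbonyl on a saturated ring carbon. In a functional assay on QGY cells (Homo sapiens) for cytotoxicity, read by MTT assay, with a stated time of 48 h (on this read-out higher numbers stand for weaker inhibition and lower numbers for stronger inhibition), compound 3 gives 48700 nM, and compound 1 gives 36700 nM, so the change made a 1.3-fold lower number from compound 3 to compound 1 (0.12 log units; within the scatter). Compound 2 `CCOC(=O)[C@@]1(C(=O)NCc2ccc(C)cc2)C[C@@H]1c1cc(OC)c(OC)c(OC)c1` has a core that differs from that of compound 3 in a way not broken down here. In this assay compound 2 gives only a limit, > 100000 nM, and so sits at the limit of > 100000 nM in this assay, at which 1 of the 3 values shown sits. Compound 4 `COc1cc([C@H]2C[C@@]2(CO)C(=O)NCc2ccc(C)cc2)cc(OC)c1OC` arises from compound 2 by the same change, (hydroxymethyl in place of ethoxycarbonyl on a saturated ring carbon). Because the earlier step of a 1.3-fold lower number from compound 3 to compound 1 (0.12 log units; within the scatter) stayed within the scatter, compound 4 is expected to end up near its parent, and for compound 4 the expected step is a step that the limit leaves unreadable from compound 2 to compound 4. Compound 4 is therefore estimated at 120000 nM, between 50000 nM and 300000 nM, and may again be reported only as a limit in this assay.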

Compound 4, half-maximal inhibitory concentration: > 100000 nM
Compound 4 was reported as a limit (the forecaster's own chance of this, stated with the estimate: 65%); the middle value is on the limit's open side.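

Compound 2 and compound 4 both stand only as limits in this assay, so the step between them cannot be read: the limit of > 100000 nM in this assay, at which 2 of the 4 values shown sit. From the compounds shown here alone, what hydroxymethyl in place of ethoxycarbonyl does on the core of compound 2 stays open.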